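Trimming an Ethyl Group to a Methyl Group

The source may report more compounds than this note shows. Statements on the series, on what has been measured and on what is new or still open speak of the compounds shown alone.

Among the measured compounds shown here, only two compounds have numbers so far in a functional assay on A549 cells (Homo sapiens) for inhibition, read by CCK-8 assay, with a stated time of 72 h, tested at 8 uM; on this read-out lower numbers stand for less inhibition of growth and higher numbers for more inhibition of growth at the one concentration tested. Compound 1 (`Nc1ccccc1NC(=O)/C=C/c1ccc(CSc2ccc(Cl)cc2)cc1`) gives 59.6%. Compound 2 (`CCc1ccc(SCc2ccc(C(=O)Nc3ccccc3N)cc2)cc1`) gives 91.4%, the higher of the two numbers, and the gap between them lies beyond the usual scatter. These two compounds differ in more than one place, so their gap cannot be pinned on any single structural change.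

Compound 3 (`Cc1ccc(SCc2ccc(C(=O)Nc3ccccc3N)cc2)cc1`) has yet to be measured. It differs from compound 2 in one place: hydrogen in place of methyl on a saturated chain carbon bound to an aromatic carbon. Put simply, hydrogen takes the place of methyl on a saturated chain carbon bound to an aromatic carbon, turning 4-ethylphenyl into 4-methylphenyl. For the measured compounds named here, no measured pair shows this change, so the data offer no direct guide to its size. The change is small, and the expectation is a slight fall in this assay that stays within the scatter. The estimated result is a number 5.4 percentage points lower from compound 2 to compound 3 (within the scatter). For compound 3 the expected value is 86%, with an estimated range from 68% to 97%.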

Compound 3, percent growth inhibition at one concentration: 78.3%
Estimate against measurement, compound 3: 7.7 percentage points above, and the stated range covers the measured number.
By their numbers in this assay, from the lowest: compound 1; then compound 3; then compound 2.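

Among the compounds shown here, this is the first comparison that isolates a single change. In this assay, trimming 4-ethylphenyl to 4-methylphenyl gives a number 13.1 percentage points lower from compound 2 to compound 3 (beyond the scatter), so this position does respond to a change as small as losing one methyl, a single carbon with no ring, no hydrogen-bond donor or acceptor, and no net charge. For the compounds shown here, nothing measured so far bears on the reason for this step.

From the compounds shown here alone, with only ethyl and methyl compared here, two points cannot establish a trend, so it remains open whether a longer chain such as propyl would raise the number further or whether the effect of chain length levels off beyond ethyl, and how a hydroxyl or an amine at the same place would compare. Going by these compounds, each number also comes from one concentration, so it also remains open whether this step would persist across a full range of concentrations or in cell lines other than the one used here.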